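The source may report more compounds than this note shows. Statements on the series, on what has been measured and on what is new or still open speak of the compounds shown alone.

Working notes on the series in an assay on CHO cells for positive allosteric modulation of metabotropic glutamate receptor 5 (Homo sapiens), read by FLIPR; on this read-out higher numbers stand for an effect only at larger amounts of compound and lower numbers for an effect already at smaller amounts.

Among the measured compounds shown here, compound 1 `O=C(CCc1cc(Cl)ccc1NC(=O)c1ccccn1)c1ccccc1` is the one member with a measured number: in this assay compound 1 gives 4500 nM. Compound 2 `COc1ccc2c(c1OC)C(=O)N(Cc1cc(Cl)ccc1NC(=O)c1ccccn1)C2=O` gives in this assay only a limit of the assay, > 100000 nM. Compound 3 `COc1ccccc1C(=O)Nc1ccc(Cl)cc1CN1C(=O)c2ccccc2C1=O` likewise gives in this assay only a limit, > 100000 nM. Compound 3 thus stands where the read-out no longer reports a number; it shares this with compound 2 (the limit of > 100000 nM in this assay, at which 2 of the 3 values shown sit), while compound 1, which differs from both at more than one place, does give a number.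

Compound 4 `O=C(Nc1ccc(Cl)cc1CN1C(=O)c2ccccc2C1=O)c1ccco1` is the next member to be measured. It differs from compound 3 in one place only (furan-2-yl in place of 2-methoxyphenyl on a carbonyl carbon). For the measured compounds named here, no step between two measured compounds is available to size this change. Given that compound 3 sits at > 100000 nM, the expectation is that the step from compound 3 to compound 4 a number no higher from compound 3 to compound 4 (the limit leaves the size open) stays within the scatter, with no gain in this assay. Compound 4 is therefore estimated at 100000 nM, in the range 30000 nM to 300000 nM, most likely again reported as a limit.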

Compound 4, half-maximal effective concentration: 2300 nM
The estimate for compound 4 lay 43-fold (1.64 log units) above the measured number; measured number outside the range, below it.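

The position on this carbonyl carbon, whose other neighbour is the amide-type nitrogen, is shown to be decisive for this core in this assay: furan-2-yl in place of 2-methoxyphenyl gives an at least 43-fold lower number from compound 3 to compound 4 (1.63 log units; beyond the scatter). The core shared by compound 3 and compound 4 can therefore give a measured number. The true size of the step stays open, as one end of it is only a limit: the limit of > 100000 nM in this assay, at which 2 of the 4 values shown sit.

The change swaps the five-membered ring for the six-membered ring and removes the methoxy group at the same time, and the compounds shown do not separate these two parts. As far as these compounds go, whether an unsubstituted phenyl or a thiophen-2-yl on this carbonyl carbon would also give a measured number remains open.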